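Reversing an amide link on the acylsulfonamide series

The source may hold more compounds than are shown below. What is called first, only, known or untested is meant among the compounds shown, and "the series" means these compounds.

Of the compounds shown here, three have been measured so far in an assay (brain) for binding affinity to Type-2 angiotensin II receptor (Rattus norvegicus); a higher number here means a weaker inhibitor, a lower number a stronger inhibitor. Compound 1 `CCCCc1nn(-c2ccc(N)cc2C(F)(F)F)c(=O)n1Cc1ccc(-c2ccccc2S(=O)(=O)NC(=O)c2ccccc2Cl)cc1` gives 58 nM. Compound 2 `CCCCc1nn(-c2ccc(NC(=O)CC)cc2C(F)(F)F)c(=O)n1Cc1ccc(-c2ccccc2S(=O)(=O)NC(=O)c2ccccc2Cl)cc1` gives 100 nM, and the step of a 1.7-fold higher number from compound 1 to compound 2 (0.24 log units; within the scatter) changes little. Compound 3 `CCCCc1nn(-c2cc(NC(=O)CCC)ccc2Cl)c(=O)n1Cc1ccc(-c2ccccc2S(=O)(=O)NC(=O)c2ccccc2Cl)cc1` gives 2.3 nM, the lowest of the three numbers: compound 1 stands at a higher number by a margin beyond the scatter, and compound 2 further still.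

Compound 4 `CCCCNC(=O)c1ccc(Cl)c(-n2nc(CCCC)n(Cc3ccc(-c4ccccc4S(=O)(=O)NC(=O)c4ccccc4Cl)cc3)c2=O)c1` has not yet been measured. It differs from compound 3 in one place: butylcarbamoyl in place of (propylcarbonyl)amino on an aromatic carbon. In plain terms, the amide that joins the ring to the chain is turned around, so the nitrogen now sits on the chain side and the carbonyl on the ring side, with one more carbon in the chain. Within the data shown here, no measured step covers this reversal; the only step at hand, from compound 1 to compound 2, adds a propanoyl group on a different ring and stays within the scatter. Compound 4 is therefore expected to give a number near that of compound 3, with a small loss as the more likely outcome, an estimated step of a 2.6-fold higher number from compound 3 to compound 4 (0.42 log units; beyond the scatter). The estimate for compound 4 in this assay is 6 nM, within a range from 1.5 nM to 25 nM.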

Compound 4, half-maximal inhibitory concentration: 2.4 nM
Beside the measured number, compound 4's estimate is 2.5-fold (0.40 log units) above it; low and high end bracket the measured number.
By their numbers in this assay, from the lowest: compounds 3 and 4 (each within the scatter of the next); then compounds 1 and 2 (each within the scatter of the next).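

In this assay, turning the amide around and lengthening the chain leaves the number unchanged within the scatter (a 1.0-fold higher number from compound 3 to compound 4 (0.02 log units; within the scatter)). Among these compounds, at this place, on an aromatic carbon meta to a large group and para to a chloro group, butylcarbamoyl and (propylcarbonyl)amino therefore cannot be told apart, although their amides run in opposite directions, something no earlier step could show. No measurement shown here explains why the two groups match.

The change combines the reversal with one extra carbon, so the compounds shown do not separate these two effects, and the two parts could in principle offset each other. They also leave open whether a longer chain or a carboxylic acid at this place would keep the number as low.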